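The source may hold more compounds than are shown below. What is called first, only, known or untested is meant among the compounds shown, and "the series" means these compounds.

Measured compounds:
compound 1 `O=C(COc1cccc2ccccc12)N/N=C/c1ccc(Cl)cc1` with 4.54
compound 2 `C/C(=N\NC(=O)COc1cccc2ccccc12)c1cccc([N+](=O)[O-])c1` with 3.37
compound 3 `O=C(COc1cccc2ccccc12)N/N=C/c1ccc(Br)cc1` with 4.81

In a physicochemical assay for lipophilicity, measured as octanol-water partition (on this read-out lower numbers stand for lower lipophilicity and higher numbers for higher lipophilicity), compound 2 gives the lowest of the three numbers; compound 1 lies higher beyond the scatter, and compound 3 higher still. Compound 4 `C/C(=N\NC(=O)COc1cccc2ccccc12)c1ccc(Cl)cc1` is not yet measured. Its change from compound 2 is 4-chlorophenyl in place of 3-nitrophenyl on a carbon with a double bond to nitrogen. Among the measured compounds shown here, the one measured step, a number 0.27 log units higher from compound 1 to compound 3 (within the scatter), swaps one halogen for another and does not touch a nitro group, so no step bears directly on this change. Compound 1, which carries 4-chlorophenyl without the nitro group, stands well above compound 2, which suggests that the step of a number 1.23 log units higher from compound 2 to compound 4 (beyond the scatter) is expected to be upward and beyond the scatter. Compound 4 is therefore estimated at 4.6, within 4.1 to 5.1.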

Compound 4, partition coefficient: 4.17
Beside the measured number, compound 4's estimate is 0.43 log units above it; measured number inside the range.
By their numbers in this assay, from the lowest: compound 2; then compound 4; then compounds 1 and 3 (each within the scatter of the next).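

Among the compounds shown here, the swap of 3-nitrophenyl for 4-chlorophenyl on a carbon with a double bond to nitrogen gives the first direct reading at this position in this assay, with a number 0.80 log units higher from compound 2 to compound 4 (beyond the scatter) for this change. The only earlier step was a halogen swap within the scatter, so this is the first single change shown that clearly moves the number.

On these data alone, the step replaces a whole group, so the shares of the lost nitro group and the gained chlorine stay unseparated, and how an amine or a carboxylic acid on that ring would read remains open. Nothing measured here gives a cause for the rise.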